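This account rests on a few compounds, and the source may have more. Where it says the series, first, only, none or still open, it means among the compounds named here.

Compound 1 `CC(O)(COc1cc(C(F)(F)F)cc(C(F)(F)F)c1)C(=O)Nc1cccc(S(F)(F)(F)(F)F)c1` is measured in a functional assay on CWR22R cells (Homo sapiens) for antiproliferative activity, read by propidium iodide staining, with a stated time of 96 h (on this read-out lower numbers stand for stronger inhibition and higher numbers for weaker inhibition), where compound 1 gives 6500 nM. Compound 2 `CC(O)(COc1ccc(S(F)(F)(F)(F)F)cc1)C(=O)Nc1cc(C(F)(F)F)cc(C(F)(F)F)c1` is built from the same atoms joined differently; the difference between the two cores is not broken down here. In this assay compound 2 gives 3200 nM, so of the three measured numbers compound 1 shows the highest. Compound 3 `CC(O)(COc1ccc(C(F)(F)C(F)(F)F)cc1)C(=O)Nc1cc(C(F)(F)F)cc(C(F)(F)F)c1` differs from compound 2 by a group of 7 heavy atoms (2 carbon, 5 fluorine; no ring) in place of a group of 6 heavy atoms (5 fluorine, 1 sulfur; no ring), on an aromatic carbon. In this assay compound 3 gives 2500 nM, and the step is a 1.3-fold lower number from compound 2 to compound 3 (0.11 log units; within the scatter). Compound 4 `CC(O)(COc1cc(C(F)(F)F)cc(C(F)(F)F)c1)C(=O)Nc1cccc(C(F)(F)C(F)(F)F)c1` is not yet measured; it differs from compound 1 by a group of 7 heavy atoms (2 carbon, 5 fluorine; no ring) in place of a group of 6 heavy atoms (5 fluorine, 1 sulfur; no ring), on an aromatic carbon. This is the same kind of change as that from compound 2 to compound 3, not the same: in compound 3 the entering group sits para to a large group, in compound 4 meta to a large group. Beside the earlier step, the expected step is a 1.3-fold lower number from compound 1 to compound 4 (0.11 log units; within the scatter). That expectation rests on the earlier step, a 1.3-fold lower number from compound 2 to compound 3 (0.11 log units; within the scatter), lying within the scatter. For compound 4 the estimated value in this assay is 5000 nM, between 2500 nM and 10000 nM.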

Compound 4, half-maximal inhibitory concentration: 4500 nM
Estimate against measurement, compound 4: 1.1-fold (0.05 log units) above, and the stated range covers the measured number.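

In this assay, putting 1,1,2,2,2-pentafluoroethyl in place of the sulfur-bearing group gives a 1.4-fold lower number from compound 1 to compound 4 (0.16 log units; within the scatter), and the change reads alike on the two cores: the same change on two cores in this assay, a 1.3-fold lower number (0.11 log units; within the scatter) from compound 2 to compound 3 and a 1.4-fold lower number (0.16 log units; within the scatter) from compound 1 to compound 4, 1.1-fold (0.05 log units) apart, within the scatter of two such steps. On these two cores the change therefore carries over without any visible dependence on the core, but both steps lie within the scatter, so neither separates the two groups. Agreement between two small steps shows only that the swap leaves the number about where it was on these cores; it does not show that the change would behave the same way on a third core, or that a larger step would transfer.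

Still open, from the compounds shown here alone, is how a nitrile, an amine, a carboxylic acid or a longer fluorinated chain would read at this place on the core of compound 1. Within the data shown here, also open is whether the close match between the two steps holds for any such group, since only this single swap has been seen on both cores.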